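Swapping a Halogen on Compound 1: Fluoro to Chloro

The source may hold more compounds than are shown below. What is called first, only, known or untested is meant among the compounds shown, and "the series" means these compounds.

Measured so far:
- compound 1, `O=C(O)/C(S)=C/c1c[nH]c2cccc(F)c12`: 10 nM
- compound 2, `O=C(O)/C(S)=C/c1ccccc1Br`: 21000 nM

Of the compounds shown here, two have been tested in an assay on isolated protein for inhibition of Calpain-1 catalytic subunit (Sus scrofa), read by FRET; a lower number here means a stronger inhibitor, a higher number a weaker inhibitor. Compound 1, built as `O=C(O)/C(S)=C/c1c[nH]c2cccc(F)c12`, gives 10 nM, the lowest of the two numbers. Compound 2, built as `O=C(O)/C(S)=C/c1ccccc1Br`, gives 21000 nM, and the gap between the two lies well beyond the scatter of repeated measurements. Going by the values given here, no step between measured compounds that differ in one place is available, so the effect of a single change has not been observed here.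

Compound 3, built as `O=C(O)/C(S)=C/c1c[nH]c2cccc(Cl)c12`, is the next compound to be tested. It differs from compound 1 by one change: chloro in place of fluoro on an aromatic carbon, on an aromatic carbon of a six-membered aromatic ring of carbon only, part of a fused system of two rings of the core of compound 1. Among the compounds with values here, with no comparable step measured, the expectation is a small step at most, in either direction or none beyond the scatter. Compound 3 is therefore estimated at 12 nM, with a range from 4 nM to 40 nM, which means an expected step from compound 1 to compound 3 of a 1.2-fold higher number from compound 1 to compound 3 (0.08 log units; within the scatter).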

Compound 3, half-maximal inhibitory concentration: 20 nM
Compound 3: the middle estimate sits 1.7-fold (0.22 log units) below what was measured, and the stated range covers the measured number.
By their numbers in this assay, from the lowest: compounds 1 and 3 (each within the scatter of the next); then compound 2.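

In this assay the change from fluoro to chloro on this aromatic carbon gives a 2.0-fold higher number from compound 1 to compound 3 (0.30 log units; within the scatter) and so the two halogens cannot be told apart at this position. This is the only step shown between compounds that differ in one place, which lets a single change be read on its own, and here that change leaves the number within the normal spread of repeated measurements. Nothing measured here bears on the reason for this result.

The compounds shown carry only halogens at this position, so it remains open whether a larger or quite different group, such as a methoxy group or an amine, would keep the number this low. One step also says nothing about how changes elsewhere on the core of compound 1 would behave.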